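Swapping iodo for cyano on the shared core

This account rests on a few compounds, and the source may have more. Where it says the series, first, only, none or still open, it means among the compounds named here.

Measured compounds in a functional assay (muscle tissue) with Cavia porcellus as the target; on this read-out higher numbers stand for an effect only at larger amounts of compound and lower numbers for an effect already at smaller amounts:
compound 1 `COC(=O)C1=C(C)N=C(C)/C(=C(\O)OC)C1c1ccccc1Cl` gives 2.19 nM
compound 2 `COC(=O)C1=C(C)N=C(C)/C(=C(\O)OC)C1c1ccccc1N` gives 39800 nM
compound 3 `COC(=O)C1=C(C)N=C(C)/C(=C(\O)OC)C1c1ccccc1I` gives 46.8 nM

Among these three, compound 3 holds the second highest number: compound 1 sits closer, with the step of a 21-fold higher number from compound 1 to compound 3 (1.33 log units; beyond the scatter), while compound 2 lies far off, with the step of an 850-fold lower number from compound 2 to compound 3 (2.93 log units; beyond the scatter) running the other way.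

Compound 4 `COC(=O)C1=C(C)N=C(C)/C(=C(\O)OC)C1c1ccccc1C#N` is not yet measured. It differs from compound 3 in one place: cyano in place of iodo on an aromatic carbon.

Among the measured compounds shown here, no measured step involves cyano, so only indirect guidance exists. The two halogen-bearing compounds, compound 1 and compound 3, give the low numbers, and the one non-halogen replacement seen so far, the step of an 18000-fold higher number from compound 1 to compound 2 (4.26 log units; beyond the scatter), produced a very large rise. Cyano, like amino and unlike iodo, is not a halogen, so a rise is the more likely direction, though its size is uncertain.

Compound 4 is therefore expected to give 600 nM in this assay, within a range of 50 nM to 10000 nM, which means an expected step of a 13-fold higher number from compound 3 to compound 4 (1.11 log units; beyond the scatter).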

Compound 4, half-maximal effective concentration: 15.9 nM
Beside the measured number, compound 4's estimate is 38-fold (1.58 log units) above it, and the stated range ends above it.
By their numbers in this assay, from the lowest: compound 1; then compound 4; then compound 3; then compound 2.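

In this assay, cyano in place of iodo gives a lower number (a 2.9-fold lower number from compound 3 to compound 4 (0.47 log units; beyond the scatter)), so a group that is not a halogen can sit on this aromatic carbon and still give a low number. Being a halogen therefore does not by itself separate the low numbers from the high one: amino stands far apart from cyano (a 2500-fold lower number from compound 2 to compound 4 (3.40 log units; beyond the scatter)), while chloro keeps the lowest number of the four (a 7.3-fold higher number from compound 1 to compound 4 (0.86 log units; beyond the scatter)). No measurement at hand explains this order.

The compounds shown leave open how bromo, fluoro, a methyl group or a carboxylic acid would fare on this same aromatic carbon. They also leave open whether the order seen in this assay holds in other tissues or species.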